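Diphenylmethyl sulfoxides on the dopamine transporter: a ring isomer

The compounds below may be only part of what the source reports. "The series", "measured", "known", "first", "only" and "open" are said of these compounds alone.

Measured so far:
compound 1 `[O-][S+](Cc1nc(O)cc(C(F)(F)F)n1)C(c1ccccc1)c1ccccc1` with 40400 nM
compound 2 `O=c1[nH]nc(C[S+]([O-])C(c2ccccc2)c2ccccc2)s1` with 38100 nM
compound 3 `Cc1nc(O)cc(C[S+]([O-])C(c2ccccc2)c2ccccc2)n1` with 3100 nM

All three numbers come from an assay on HEK293 cells for inhibition of sodium-dependent dopamine transporter (Homo sapiens), read by scintillation counting, with stated times of 5 min and 1 min; on this read-out higher numbers stand for weaker inhibition and lower numbers for stronger inhibition. Compound 3 gives the lowest number of the three; its nearest neighbour is compound 2, with the step of a 12-fold lower number from compound 2 to compound 3 (1.09 log units; beyond the scatter) carrying the six-membered ring in place of the five-membered one, and compound 1 sits further off still, at a number of the same order as compound 2.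

Compound 4 `Cc1cc(O)nc(C[S+]([O-])C(c2ccccc2)c2ccccc2)n1` is the one still to be measured. The change from compound 3 is 4-hydroxy-6-methylpyrimidin-2-yl in place of 6-hydroxy-2-methylpyrimidin-4-yl on a saturated chain carbon bound to a sulfur, so the two compounds hold the same atoms, joined differently, and the hydroxyl and methyl swap their places on the ring.

For the measured compounds named here, no measured step bears directly on such a swap. Going by the values given here, the only step in hand, from compound 2 to compound 3, changed the ring type itself and was large, which shows that this assay reacts strongly to what sits on the saturated chain carbon bound to a sulfur. Among the compounds with values here, a rearrangement within the same ring is a smaller change than that, and with no matching pair the direction is open; a modest move toward a higher number is taken as the central expectation, within wide bounds.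

For compound 4 in this assay the expected step is a 1.6-fold higher number from compound 3 to compound 4 (0.21 log units; within the scatter). Compound 4 is therefore estimated at 5000 nM, with a range from 1500 nM to 20000 nM.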

Compound 4, half-maximal inhibitory concentration: 109000 nM
Estimate against measurement, compound 4: 22-fold (1.34 log units) below; measured number outside the range, above it.
By their numbers in this assay, from the lowest: compound 3; then compounds 2 and 1 (each within the scatter of the next); then compound 4.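

In this assay the swap alone, with the same atoms and the same printed counts on both sides, gives a 35-fold higher number from compound 3 to compound 4 (1.55 log units; beyond the scatter) and is a large step, so the arrangement of hydroxyl and methyl on the pyrimidine ring matters here and not only the ring type. The six-membered ring therefore brings no low number by itself: the earlier ring change read a 12-fold lower number from compound 2 to compound 3 (1.09 log units; beyond the scatter) but with the 4-hydroxy-6-methylpyrimidin-2-yl group the same kind of change reads a 2.9-fold higher number from compound 2 to compound 4 (0.46 log units; beyond the scatter) in the opposite direction, and the low number in this small set belongs to the 6-hydroxy-2-methylpyrimidin-4-yl group alone. Within the 2-yl arrangement, the exchange on an aromatic carbon gives a 2.7-fold higher number from compound 1 to compound 4 (0.43 log units; beyond the scatter) and is only modest, so neither methyl nor trifluoromethyl brings that arrangement near the number of compound 3.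

As far as these compounds go, whether the 6-hydroxy-2-methylpyrimidin-4-yl group keeps its low number with an amine in place of the hydroxyl, or with a longer chain in place of the methyl, stays open. Nothing in hand gives a reason for the size of the swap.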